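This account rests on a few compounds, and the source may have more. Where it says the series, first, only, none or still open, it means among the compounds named here.

In a functional assay on HSC-3 cells (Homo sapiens) for cytotoxicity (a lower number here means that less compound is tolerated, a higher number that more compound is tolerated), compound 2 `O=C1/C(=C/c2ccc(O)cc2)Cc2ccccc2/C1=C\c1ccc([N+](=O)[O-])cc1` gives 14000 nM, while compound 1 `COc1ccc(/C=C2\Cc3ccccc3/C(=C\c3ccc([N+](=O)[O-])cc3)C2=O)cc1`, which differs from it by methyl in place of hydrogen on an oxygen on an aromatic ring, gives 32000 nM. That change made a 2.3-fold higher number from compound 2 to compound 1 (0.36 log units; beyond the scatter). Compound 3 `O=C1/C(=C/c2ccc(O)cc2)CCC/C1=C\c1ccc([N+](=O)[O-])cc1` gives 13000 nM in this assay; its core differs from the core of compound 2, and that difference is not broken down here. Compound 4 `COc1ccc(/C=C2\CCC/C(=C\c3ccc([N+](=O)[O-])cc3)C2=O)cc1` has not been measured. Going by the values given here, it differs from compound 3 by methyl in place of hydrogen on an oxygen on an aromatic ring, the same change as the one between compound 2 and compound 1, in the same place. Compound 4 is therefore expected to show a 2.3-fold higher number from compound 3 to compound 4 (0.36 log units; beyond the scatter), a step set beside the earlier one. This expectation rests on compound 3 giving 13000 nM and on the measured step of a 2.3-fold higher number from compound 2 to compound 1 (0.36 log units; beyond the scatter). The estimate for compound 4 is 30000 nM, expected to lie between 15000 nM and 60000 nM.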

Compound 4, half-maximal cytotoxic concentration: > 400000 nM
Compound 4: no number, only a limit; the forecaster's own chance of this, stated with the estimate: 10%; middle value at least 13-fold (1.12 log units) away from the limit.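

In this assay, going by these compounds alone, methyl in place of hydrogen on the oxygen gives an at least 30-fold higher number from compound 3 to compound 4 (1.48 log units; beyond the scatter), so the direction is the same on both cores but the size is not: the same change on two cores in this assay, a 2.3-fold higher number (0.36 log units; beyond the scatter) from compound 2 to compound 1 and an at least 30-fold higher number (1.48 log units; beyond the scatter) from compound 3 to compound 4, at least 13-fold (1.12 log units) apart, beyond the scatter of two such steps Compound 4 gives > 400000 nM, which is a limit of the assay and not a number: the limit of > 400000 nM in this assay, at which 1 of the 4 values shown sits. With only one pair on each core, this shows that the step on one core did not predict the step on the other, but it does not show why they differ or how large the step on the core of compound 3 really is.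

The compounds shown leave open whether an ethyl group or a longer chain on that oxygen would separate the two cores in the same way. They also leave open how an amine in place of the hydroxy would behave on either core.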